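Chain extension on the quaternary nitrogen: compound 2 to compound 3

The compounds below may be only part of what the source reports. "The series", "measured", "known", "first", "only" and "open" are said of these compounds alone.

In a functional assay (strain AB) with Danio rerio as the target, read by microscopy, with a stated time of 1 h (a lower number here means that less compound is needed, a higher number that more compound is needed for the effect), compound 2 (`CC[N+]1(C)CCc2c(sc(NC(=O)Nc3ccc(Cl)cc3)c2C(N)=O)C1`) gives 1960 nM, the higher of the two numbers, while compound 1 (`CC(C)(C)OC(=O)CCCC[N+]1(C)CCc2c(sc(NC(=O)Nc3ccc(Cl)cc3)c2C(N)=O)C1`) gives 140 nM. Compound 3 (`COCCC[N+]1(C)CCc2c(sc(NC(=O)Nc3ccc(Cl)cc3)c2C(N)=O)C1`) has methoxymethyl in place of hydrogen on a saturated chain carbon, two bonds along the chain from an amine nitrogen in a ring. Among the compounds with values here, the only measured step at this place is a 14-fold higher number from compound 1 to compound 2 (1.15 log units; beyond the scatter). Read in reverse, it suggests a lower number, but compound 3 lacks the tert-butoxycarbonyl group, so a smaller move is expected. The expected step is a 2.6-fold lower number from compound 2 to compound 3 (0.42 log units; beyond the scatter). The estimated value for compound 3 is 750 nM, with a range of 250 nM to 2000 nM.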

Compound 3, half-maximal effective concentration: 480 nM
The estimate for compound 3 lay 1.6-fold (0.19 log units) above the measured number, within the range that was stated.
By their numbers in this assay, from the lowest: compound 1; then compound 3; then compound 2.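

In this assay the change from ethyl to 3-methoxypropyl brings a 4.1-fold lower number from compound 2 to compound 3 (0.61 log units; beyond the scatter) without any tert-butoxycarbonyl group, so a lower number at this place on the chain does not require that group. Methoxy in place of (tert-butoxycarbonyl)methyl gives a 3.4-fold higher number from compound 1 to compound 3 (0.54 log units; beyond the scatter) and so compound 1 keeps the lowest number of the three. No evidence on the cause of either step is available.

Open, from the compounds shown here alone, is whether the chain length or the methoxy oxygen carries the change, which a plain butyl chain would separate. Going by these compounds, a carboxylic acid or an amine at the chain end also remains open.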